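The source may report more compounds than this note shows. Statements on the series, on what has been measured and on what is new or still open speak of the compounds shown alone.

Series notes. Compound 1 `C[C@H]1C[C@H]1C(=O)N1CC2CNCC2C1` carries a 2-methylcyclopropyl on the carbonyl carbon; compound 2 `CC(=O)N1CC2CNCC2C1` carries a methyl there, and compound 3 `CCC(=O)N1CC2CNCC2C1` an ethyl. Among the measured compounds shown here, in an assay on SHEP1 cells for displacement of a labelled ligand from Neuronal acetylcholine receptor; alpha4/beta2 (Homo sapiens), read by scintillation counting, with a stated time of 2 h (on this read-out lower numbers stand for stronger inhibition and higher numbers for weaker inhibition), compound 1 gives 18 nM, the lowest of the two numbers measured so far; compound 2 gives 38 nM. For the measured compounds named here, the one step measured between them, a 2.1-fold higher number from compound 1 to compound 2 (0.32 log units; beyond the scatter), shows a modest shift on trimming the carbonyl substituent. Compound 3 differs from compound 1 by ethyl in place of 2-methylcyclopropyl on a carbonyl carbon. Going by the values given here, the step to compound 2 is the only one bearing on this change, and ethyl lies between methyl and 2-methylcyclopropyl in the count of carbon atoms it brings, so a modest rise in this assay, no larger than that from compound 1 to compound 2, is expected, a 1.7-fold higher number from compound 1 to compound 3 (0.22 log units; within the scatter). Compound 3 is therefore estimated at 30 nM, with a range of 12 nM to 70 nM.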

Compound 3, inhibition constant: 12 nM
Compound 3: the middle estimate sits 2.5-fold (0.40 log units) above what was measured; low and high end bracket the measured number.
By their numbers in this assay, from the lowest: compounds 3 and 1 (each within the scatter of the next); then compound 2.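

In this assay, the ring and the two defined stereocentres of the 2-methylcyclopropyl group prove dispensable on this carbonyl carbon: ethyl in its place gives a 1.5-fold lower number from compound 1 to compound 3 (0.18 log units; within the scatter), so compound 1 and compound 3 cannot be told apart. The shift at this position comes with the smallest extension, since methyl in place of hydrogen on the saturated chain carbon bound to the carbonyl carbon gives a 3.2-fold lower number from compound 2 to compound 3 (0.50 log units; beyond the scatter), and a number as low as that of compound 1 is thus reached without any ring. Nothing at hand bears on why the numbers fall this way.

Still open, going by these compounds, is whether a longer chain such as propyl or butyl keeps the number of compound 3 or loses it. Equally open, on these data alone, is how a chain ending in an amine or a hydroxyl would fare on this carbonyl carbon.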